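Benzylsulfanyl for pentyloxy: notes on tolerated concentration

This account rests on a few compounds, and the source may have more. Where it says the series, first, only, none or still open, it means among the compounds named here.

Measured in an ADME assay on Akata cells (Homo sapiens) for cytotoxicity, with a stated time of 7 days; a higher number here means that more compound is tolerated, a lower number that less compound is tolerated:
- compound 1 `CCCSc1nc(N)nc2c1ncn2/C=C1/CC1(CO)CO`: > 20000 nM
- compound 2 `CSc1nc(N)nc2c1ncn2/C=C1/CC1(CO)CO`: > 20000 nM
- compound 3 `CCCCCOc1nc(N)nc2c1ncn2/C=C1/CC1(CO)CO`: > 20000 nM

All three entries are limits, not numbers. Compound 3 stands only at a limit, > 20000 nM. The series as a whole shows (the limit of > 20000 nM in this assay, at which 3 of the 3 values shown sit).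

Compound 4 `Nc1nc(SCc2ccccc2)c2ncn(/C=C3/CC3(CO)CO)c2n1` carries benzylsulfanyl in place of pentyloxy on an aromatic carbon.

Two measured changes replace a group on the same aromatic carbon: a step that the two limits leave unreadable from compound 1 to compound 3 and a step that the two limits leave unreadable from compound 2 to compound 3. The chain change gives a step that the two limits leave unreadable from compound 1 to compound 2. Going by the values given here, none of these has a readable size, so no sized step or direction can be carried over, and this assay is expected to return a limit again.

Compound 4 is estimated at 20000 nM, with an expected range of 9000 nM to 40000 nM. The expected step is a number no higher from compound 3 to compound 4 (the limit leaves the size open).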

Compound 4, half-maximal cytotoxic concentration: > 20000 nM
Compound 4 was reported as a limit (the forecaster's own chance of this, stated with the estimate: 80%); the middle value lies on the limit itself.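

In this assay, going by these compounds alone, compound 4 gives > 20000 nM, a limit, so no step between it and compound 1, compound 2 or compound 3 can be read. The compounds shown leave open whether these groups on the aromatic carbon differ in tolerated concentration at all.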